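A few compounds are considered here, and "the series" means these few. Any claim that something is new, unique, unknown or untested is made for them only; others in the source may bear on it.

In an ADME assay on HepG2 2.2.15 cells (Homo sapiens) for cytotoxicity, read by MTT assay (on this read-out higher numbers stand for lower toxicity in this test and lower numbers for higher toxicity in this test), compound 1 `CC(=O)c1ccc(O[C@@H]2O[C@H](COC(=O)/C=C/c3ccc(F)c(F)c3)[C@@H](O)[C@H](O)[C@H]2O)cc1` gives 874000 nM. Compound 2 `CC(=O)c1ccc(O[C@@H]2O[C@H](COC(=O)c3cccnc3)[C@@H](O)[C@H](O)[C@H]2O)cc1` gives > 1650000 nM, which is a limit of the assay and not a number. This places compound 2 at the limit of > 1650000 nM in this assay, at which 1 of the 2 values shown sits.

Compound 3 `CC(=O)c1ccc(O[C@@H]2O[C@H](COC(=O)c3ccco3)[C@@H](O)[C@H](O)[C@H]2O)cc1` differs from compound 2 by one change, furan-2-yl in place of pyridin-3-yl on a carbonyl carbon.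

Within the data shown here, the only measured step at this carbonyl carbon is an at least 1.8-fold higher number from compound 1 to compound 2 (0.27 log units; that floor lies within the scatter). It is a floor and gives no firm size for a replacement here. No step beyond the scatter is therefore expected in this assay, and no direction can be favoured. A further limit reading is also plausible for compound 3. The estimated change is an at least 1.0-fold lower number from compound 2 to compound 3 (0.01 log units; that floor lies within the scatter), which is expected to stay within the scatter. Compound 3 is estimated at 1600000 nM, with an expected range of 750000 nM to 3300000 nM.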

Compound 3, half-maximal cytotoxic concentration: 1170000 nM
Estimate against measurement, compound 3: 1.4-fold (0.14 log units) above; the range from low to high includes it.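

In this assay, this carbonyl carbon now has a second exact reading. Among these compounds, the step of a 1.3-fold higher number from compound 1 to compound 3 (0.13 log units; within the scatter) shows that furan-2-yl and 2-(3,4-difluorophenyl)ethenyl are not separated at this position, a replacement of a different kind from the one in the earlier step, since the ring here is five-membered and sits directly on the carbonyl carbon. The change from pyridin-3-yl reads only as a floor, an at least 1.4-fold lower number from compound 2 to compound 3 (0.14 log units; that floor lies within the scatter), and the reading for compound 2 remains a limit of the assay and not a number: the limit of > 1650000 nM in this assay, at which 1 of the 3 values shown sits.

From the compounds shown here alone, it remains open whether any replacement on this carbonyl carbon can move the number beyond the scatter. Also open, going by these compounds, is how a saturated ring carrying an amine, or a chain ending in a carboxylic acid, would read there.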